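A few compounds are considered here, and "the series" means these few. Any claim that something is new, unique, unknown or untested is made for them only; others in the source may bear on it.

Measured so far in an in vitro ADME assay on microsomes from liver (Homo sapiens) for metabolic stability, tested at 1 uM; on this read-out lower numbers stand for slow clearance and higher numbers for fast clearance:
- compound 1 `Cn1c(CN2C[C@@H]3C(COc4ccccc4)[C@@H]3C2)nc2ccccc21` gives 14.2 mL/min/kg
- compound 2 `Cn1c(CN2C[C@@H]3C(COc4cc(F)ccc4F)[C@@H]3C2)nc2ccccc21` gives > 18.7 mL/min/kg, which is a limit of this assay and not a number

Going by the values given here, compound 2 therefore stands at the limit of > 18.7 mL/min/kg in this assay, at which 1 of the 2 values shown sits; only a limit is known for it, and compound 1 is the sole compound of the pair with a number. Among the compounds with values here, the one measured step, an at least 1.3-fold higher number from compound 1 to compound 2 (0.11 log units; that floor lies within the scatter), changed the group on the same oxygen.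

Compound 3 `CC(C)c1ccc(OCC2[C@H]3CN(Cc4nc5ccccc5n4C)C[C@@H]23)cc1` is not yet measured. It differs from compound 2 by 4-isopropylphenyl in place of 2,5-difluorophenyl on an oxygen on a saturated carbon. Within the data shown here, the one measured step bears on it only in that it also altered the aryl group on that oxygen, and since its floor lies within the scatter it gives no usable size for the new change. With compound 2 already at the limit of this assay, compound 3 is expected to sit near or beyond that limit as well; the estimated step that the limit leaves unreadable from compound 2 to compound 3 is expected to stay within the scatter. The estimate for compound 3 in this assay is 24 mL/min/kg, with a range from 14 mL/min/kg to 40 mL/min/kg.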

Compound 3, clearance: 5.8 mL/min/kg
The estimate for compound 3 lay 4.1-fold (0.62 log units) above the measured number; the measured number lies below the stated range.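

In this assay, the aryl group on the oxygen on a saturated carbon now shows a step that can be read beyond the scatter: isopropyl in place of hydrogen on an aromatic carbon gives a 2.4-fold lower number from compound 1 to compound 3 (0.39 log units; beyond the scatter). The other new comparison, 4-isopropylphenyl in place of 2,5-difluorophenyl, gives an at least 3.2-fold lower number from compound 2 to compound 3 (0.50 log units; beyond the scatter), so its size is a floor and the true gap may be wider. Compound 2 carries a limit and not a number: the limit of > 18.7 mL/min/kg in this assay, at which 1 of the 3 values shown sits.

The compounds shown leave open whether the lower number goes with isopropyl as such or would also appear with a methyl or a tert-butyl group on the phenyl. They also leave open whether a nitrile or a methoxy group in the same place would move the number the same way.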